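The source may hold more compounds than are shown below. What is called first, only, known or untested is meant among the compounds shown, and "the series" means these compounds.

In a physicochemical assay for lipophilicity (on this read-out higher numbers stand for higher lipophilicity and lower numbers for lower lipophilicity), compound 2 (`C[C@H]1CC[C@@H]2[C@@H](OC(=O)[C@]23CC(c2ccccc2)N(c2ccccc2)O3)[C@]2(C)C(=O)C=C[C@@]12O`) gives 3.19, within the scatter of compound 1 (`C[C@H]1CC[C@@H]2[C@@H](OC(=O)[C@]23CC(c2ccc(F)cc2)N(c2ccccc2)O3)[C@]2(C)C(=O)C=C[C@@]12O`) at 3.35. Compound 3 (`COc1ccc(C2C[C@@]3(ON2c2ccccc2)C(=O)O[C@@H]2[C@H]3CC[C@H](C)[C@]3(O)C=CC(=O)[C@@]23C)cc1Br`) has 3-bromo-4-methoxyphenyl in place of phenyl on a saturated ring carbon. For the measured compounds named here, only one measured step bears on this, a number 0.16 log units lower from compound 1 to compound 2 (within the scatter), which is hydrogen in place of fluoro on an aromatic carbon and lies within the scatter. It is a different and smaller change, so it guides the size only loosely. An upward move beyond the scatter is expected, with the estimated step being a number 0.61 log units higher from compound 2 to compound 3 (beyond the scatter). The estimate for compound 3 is 3.8, with an expected range of 3.4 to 4.2.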

Compound 3, partition coefficient: 3.98
Beside the measured number, compound 3's estimate is 0.18 log units below it; the measured number falls inside the stated range.
By their numbers in this assay, from the lowest: compounds 2 and 1 (each within the scatter of the next); then compound 3.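

On the saturated ring carbon, the aryl group now moves the read-out beyond the scatter in this assay, with a number 0.79 log units higher from compound 2 to compound 3 (beyond the scatter) for 3-bromo-4-methoxyphenyl in place of phenyl. The step is of similar direction against the fluorinated aryl group, with a number 0.63 log units higher from compound 1 to compound 3 (beyond the scatter) for 3-bromo-4-methoxyphenyl in place of 4-fluorophenyl, whereas the earlier pair stayed within the scatter. No supporting data bear on the cause of these steps.
From the compounds shown here alone, the bromo and methoxy parts enter together, so their separate shares stay open. Going by these compounds, how an amine or a carboxylic acid on this aromatic ring would read also stays open.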